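The source may hold more compounds than are shown below. What is called first, only, known or untested is meant among the compounds shown, and "the series" means these compounds.

Of the compounds shown here, two sharing one core have been measured in an assay on CHO cells for displacement of a labelled ligand from adenosine receptor A1 (Homo sapiens), read by scintillation counting, with a stated time of 60 min, tested at 10 uM; on this read-out lower numbers stand for less inhibition and higher numbers for more inhibition at the one concentration tested (going by the name of the read-out). Compound 1 `CNC(=O)[C@@]12C[C@@H]1[C@@H](n1cnc3c(NC)nc(C#Cc4ccc(Cl)cc4)nc31)[C@H](O)[C@@H]2O` gives 13%. Going by the values given here, compound 2 `CNC(=O)[C@@]12C[C@@H]1[C@@H](n1cnc3c(NC)nc(C#Cc4cnn(C)c4)nc31)[C@H](O)[C@@H]2O` gives 35%, the higher of the two numbers, and the only other number, that of compound 1, lies beyond the scatter below it: a number 22 percentage points higher from compound 1 to compound 2 (beyond the scatter). Compound 3 `CCc1ccc(C#Cc2nc(NC)c3ncn([C@H]4[C@H](O)[C@H](O)[C@]5(C(=O)NC)C[C@H]45)c3n2)o1` has not yet been measured; it differs from compound 2 in one place, (5-ethylfuran-2-yl in place of 1-methyl-1H-pyrazol-4-yl on a triple-bonded carbon). Among the compounds with values here, the one measured step that bears on this change is the step from compound 1 to compound 2, which swapped the group on the same triple-bonded carbon and raised the number by a modest amount. That step shows the group at this place can shift the read-out beyond the scatter, but it gives no direction for the entering group. The step from compound 2 to compound 3 is therefore expected to be small, a number 10 percentage points lower from compound 2 to compound 3 (within the scatter), with a drop thought somewhat more likely than a rise. Compound 3 is estimated at 25%, between 8% and 45%.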

Compound 3, a percentage reported as inhibition, at one concentration (the size of the read-out at that concentration, not a potency): 18%
Estimate against measurement, compound 3: 7 percentage points above; measured number inside the range.
By their numbers in this assay, from the lowest: compounds 1 and 3 (each within the scatter of the next); then compound 2.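

In this assay, 5-ethylfuran-2-yl in place of 1-methyl-1H-pyrazol-4-yl on the triple-bonded carbon gives a number 17 percentage points lower from compound 2 to compound 3 (beyond the scatter), so a second ring swap at this place also moves the number beyond the scatter, this time downward. The 5-ethylfuran-2-yl and 4-chlorophenyl groups cannot be told apart here, with a number 5 percentage points higher from compound 1 to compound 3 (within the scatter), so of these three groups only 1-methyl-1H-pyrazol-4-yl stands apart, even though the furan also has a five-membered aromatic ring. Nothing measured here explains why these groups give these numbers.

The pyrazole and furan groups differ in their ring atoms and in their methyl and ethyl groups, so the compounds shown cannot say which difference matters. Also open, on these data alone, is how a ring carrying an amine or a carboxylic acid would read at this place.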